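This account rests on a few compounds, and the source may have more. Where it says the series, first, only, none or still open, it means among the compounds named here.

Compound 1 `Cc1ccc(/C=C2/S/C(=N/c3ccccc3)N(Cc3ccncc3)C2=O)cc1`: 19700 nM
Compound 2 `O=C1/C(=C\c2ccc(O)cc2)S/C(=N/c2ccccc2)N1Cc1ccncc1`: 11800 nM
Compound 3 `COc1ccc(/C=C2/S/C(=N/c3ccccc3)N(Cc3ccncc3)C2=O)cc1`: 19100 nM

In a functional assay on HepG2 cells (Homo sapiens) for cytotoxicity, read by MTT assay, with a stated time of 48 h (on this read-out higher numbers stand for weaker inhibition and lower numbers for stronger inhibition), compound 3 gives 19100 nM, within the scatter of both neighbours: a 1.0-fold lower number from compound 1 to compound 3 (0.01 log units; within the scatter) and a 1.6-fold higher number from compound 2 to compound 3 (0.21 log units; within the scatter). Compound 4 `O=C1/C(=C\c2ccc([N+](=O)[O-])cc2)S/C(=N/c2ccccc2)N1Cc1ccncc1` carries nitro in place of methoxy on an aromatic carbon, para to a large group (nitro in place of methoxy on an aromatic carbon). Within the data shown here, no measured compound carries nitro, so the evidence is indirect. The same position has so far tolerated exchange without a step beyond the scatter: a 1.7-fold lower number from compound 1 to compound 2 (0.22 log units; within the scatter), alongside the two steps above. Three compounds make a thin basis, but no step beyond the scatter is expected, and no direction is favoured. The estimated step is a 1.2-fold lower number from compound 3 to compound 4 (0.08 log units; within the scatter). For compound 4 the estimate is 16000 nM, with an expected range of 7500 nM to 33000 nM.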

Compound 4, half-maximal inhibitory concentration: 18900 nM
Compound 4: middle estimate off by 1.2-fold (0.07 log units), on the low side; the measured number falls inside the stated range.
By their numbers in this assay, from the lowest: compounds 2, 4, 3 and 1 (each within the scatter of the next).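

Nitro at this place, on an aromatic carbon para to a large group, also gives no step beyond the scatter in this assay: a 1.0-fold lower number from compound 3 to compound 4 (0.00 log units; within the scatter) and a 1.6-fold higher number from compound 2 to compound 4 (0.20 log units; within the scatter) and a 1.0-fold lower number from compound 1 to compound 4 (0.02 log units; within the scatter). Methyl, hydroxy, methoxy and nitro therefore cannot be told apart here, so the tolerance seen among the first three groups now extends to a group with a double bond outside aromatic rings. No measured property is available to bear on this result.

As far as these compounds go, whether an amine, a carboxylic acid or a longer chain at this place would give a step beyond the scatter remains open. From the compounds shown here alone, the effect of changes elsewhere on the shared core also remains open.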